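Swapping the trichloromethyl for a nitrophenyl group

The source may report more compounds than this note shows. Statements on the series, on what has been measured and on what is new or still open speak of the compounds shown alone.

Of the compounds shown here, two from this series have been measured. Compound 1 `O=c1nc(O)ccn1[C@H]1C[C@H](SS[C@H]2C[C@H](n3ccc(O)nc3=O)O[C@@H]2CO)[C@@H](CO)O1` is one of them. Compound 2 `Cc1cn([C@H]2C[C@H](SSC(Cl)(Cl)Cl)[C@@H](CO)O2)c(=O)[nH]c1=O` is the other. Among the measured compounds shown here, in an ADME assay on CCRF-CEM cells (Homo sapiens) for cytotoxicity (a higher number here means that more compound is tolerated, a lower number that less compound is tolerated), compound 2 gives 103000 nM, the only plain number in the set. Compound 1 reaches only the limit of the assay, >= 250000 nM, so no number is known for it; this is the limit (the limit of >= 250000 nM in this assay, at which 1 of the 2 values shown sits). For the measured compounds named here, because only one number stands, no measured step between two compounds can be described.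

Compound 3 `Cc1cn([C@H]2C[C@H](SSc3ccc([N+](=O)[O-])cc3)[C@@H](CO)O2)c(=O)[nH]c1=O` has not yet been measured. It differs from compound 2 in a single spot: 4-nitrophenyl in place of trichloromethyl on a sulfur. Going by the values given here, with no measured step on record, the expectation for compound 3 rests on compound 2 alone. The step is expected to stay roughly where compound 2 sits, perhaps drifting a little toward less compound being tolerated, though not clearly beyond the scatter: a 1.3-fold lower number from compound 2 to compound 3 (0.11 log units; within the scatter) is the expected change. Compound 3 is therefore estimated at 80000 nM in this assay, within a range from 25000 nM to 250000 nM.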

Compound 3, half-maximal cytotoxic concentration: 23000 nM
Beside the measured number, compound 3's estimate is 3.5-fold (0.54 log units) above it, outside the stated range (below it).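

Among the compounds shown here, this is the first measured step, and it shows that the group on a sulfur whose other neighbour is sulfur matters for the read-out: in this assay, 4-nitrophenyl in place of trichloromethyl gives a 4.5-fold lower number from compound 2 to compound 3 (0.65 log units; beyond the scatter). The move from a group with no ring to one with an aromatic ring therefore shifts the result toward less compound being tolerated, by more than repeated measurements would scatter, although this rests on a single pair of compounds. No measurement shown bears on the reason for this step.

The compounds shown leave open whether the aromatic ring alone or the nitro group on it accounts for the step, a question that plain phenyl, or a phenyl ring carrying an amine in place of the nitro group, would help to answer. Going by these compounds, it also remains open whether a simple butyl chain on this sulfur would give a number closer to that of compound 2 or to that of compound 3.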